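The source may hold more compounds than are shown below. What is called first, only, known or untested is meant among the compounds shown, and "the series" means these compounds.

Compound 1 `CCOC(=O)N1CCCc2cc(S(=O)(=O)N3CC(c4ccccc4)NC3=O)ccc21`: 344 nM
Compound 2 `CCCCOC(=O)N1CCCc2cc(S(=O)(=O)N3CC(c4ccccc4)NC3=O)ccc21`: > 20000 nM

Both were tested in a functional assay on A549 cells (Homo sapiens) for antiproliferative activity, read by MTT assay; on this read-out lower numbers stand for stronger inhibition and higher numbers for weaker inhibition. Compound 2 stands only at a limit of the assay, not at a number: the limit of > 20000 nM in this assay, at which 1 of the 2 values shown sits.

Compound 3 `C=CCOC(=O)N1CCCc2cc(S(=O)(=O)N3CC(c4ccccc4)NC3=O)ccc21` differs from compound 2 by one change, butoxycarbonyl to allyloxycarbonyl: vinyl in place of propyl on a saturated chain carbon bound to an oxygen next to a carbonyl group.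

Among the measured compounds shown here, only one measured step bears on this, an at least 58-fold higher number from compound 1 to compound 2 (1.76 log units; beyond the scatter). It is large, and on that evidence compound 3 is expected to recover part of that gap and land between the two.

The estimated change is an at least 10-fold lower number from compound 2 to compound 3 (1.00 log units; beyond the scatter), towards stronger inhibition. For compound 3 the expected value is 2000 nM, with a range of 400 nM to 15000 nM.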

Compound 3, half-maximal inhibitory concentration: 4310 nM
Estimate against measurement, compound 3: 2.2-fold (0.33 log units) below; the range from low to high includes it.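

In this assay, allyloxycarbonyl keeps measurable activity where butoxycarbonyl does not, with an at least 4.6-fold lower number from compound 2 to compound 3 (0.66 log units; beyond the scatter). The value of compound 2 is a limit of the assay, not a number: the limit of > 20000 nM in this assay, at which 1 of the 3 values shown sits. Ethoxycarbonyl still remains clearly ahead, with a 13-fold higher number from compound 1 to compound 3 (1.10 log units; beyond the scatter), so most of the loss at this position already appears with allyl and does not require the full butyl chain.

Still open, going by these compounds, is whether the double bond or only chain length sets this result. A propoxycarbonyl group would match allyl in chain length without the double bond, and a methoxycarbonyl group would show whether a shorter chain does better still.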